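Working notes: chloro to trifluoromethyl on the urea aryl

The source may hold more compounds than are shown below. What is called first, only, known or untested is meant among the compounds shown, and "the series" means these compounds.

Measured so far:
compound 1 `O=C(Nc1cccc(-n2cc(-c3ccncc3)c(-c3ccc(Cl)c(O)c3)n2)c1)Nc1ccc(Cl)c(Cl)c1` — 3960 nM
compound 2 `COc1cc(-c2nn(-c3cccc(NC(=O)c4ccc(Cl)c(C(F)(F)F)c4)c3)cc2-c2ccncc2)ccc1Cl` — 6140 nM
compound 3 `COc1cc(-c2nn(-c3cccc(NC(=O)c4ccccc4)c3)cc2-c2ccncc2)ccc1Cl` — 522 nM

In a functional assay on COLO 205 cells (Homo sapiens) for inhibition, read by sulforhodamine B assay, with a stated time of 48 h (a lower number here means a stronger inhibitor of growth, a higher number a weaker inhibitor of growth), compound 1 gives 3960 nM, the second highest of the three numbers; compound 2 lies within the scatter of it, compound 3 beyond the scatter below it. Compound 4 `O=C(Nc1cccc(-n2cc(-c3ccncc3)c(-c3ccc(Cl)c(O)c3)n2)c1)Nc1ccc(Cl)c(C(F)(F)F)c1` differs from compound 1 by trifluoromethyl in place of chloro on an aromatic carbon. Among the measured compounds shown here, the only measured step, a 12-fold lower number from compound 2 to compound 3 (1.07 log units; beyond the scatter), sits in the amide pair and swaps the whole 4-chloro-3-(trifluoromethyl)phenyl for phenyl, so it bears only loosely here. Compound 2 already carries the 4-chloro-3-(trifluoromethyl)phenyl group, and its number is within the scatter of compound 1. No step beyond the scatter is therefore expected, and compound 4 is estimated at 4500 nM (range 1500 nM to 13000 nM), a step of a 1.1-fold higher number from compound 1 to compound 4 (0.06 log units; within the scatter).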

Compound 4, concentration for 50% growth inhibition: 2390 nM
Compound 4: the middle estimate sits 1.9-fold (0.27 log units) above what was measured; the measured number falls inside the stated range.
By their numbers in this assay, from the lowest: compound 3; then compounds 4, 1 and 2 (each within the scatter of the next, the first and the last beyond it).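

Trifluoromethyl in place of chloro on the urea aryl, ortho to a chloro group, gives a 1.7-fold lower number from compound 1 to compound 4 (0.22 log units; within the scatter) in this assay, so going from one to four heavy atoms at this position produces no step beyond the scatter. Among the compounds shown here, this is the first step read within the urea pair, and it is much smaller than a 12-fold lower number from compound 2 to compound 3 (1.07 log units; beyond the scatter), which takes out the whole substituted aryl of the amide pair rather than one group. No measurement here bears on the reason for this result.

Still open, going by these compounds, is whether the urea tolerates an unsubstituted phenyl, as the amide pair does. Also open, on these data alone, is how a methoxy group or an amine at this position would compare.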